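Adding a Second Vinylcarbonyl Ester to Compound 2

The source may report more compounds than this note shows. Statements on the series, on what has been measured and on what is new or still open speak of the compounds shown alone.

Within the data shown here, compound 2 `C=CC(=O)Oc1ccc(/C=C/C(=O)c2c(OC)cc3c(c2O)CCC(C)(C)O3)cc1` is the only compound here with a numbered result: in an assay on HEK293T cells for inhibition of nuclear factor NF-kappa-B complex (Homo sapiens), read by a luciferase reporter (on this read-out higher numbers stand for weaker inhibition and lower numbers for stronger inhibition), compound 2 gives 8990 nM. Compound 1 `COc1cc2c(c(O)c1C(=O)/C=C/c1ccc(OC(=O)c3ccc(Cl)nc3)cc1)CCC(C)(C)O2` reaches only a limit of the method, giving > 30000 nM in this assay. Among the measured compounds shown here, the step of an at least 3.3-fold lower number from compound 1 to compound 2 (0.52 log units; beyond the scatter) is the sole measured change, and its size can only be read against (the limit of > 30000 nM in this assay, at which 1 of the 2 values shown sits). Compound 3 `C=CC(=O)Oc1ccc(/C=C/C(=O)c2c(OC)cc3c(c2OC(=O)C=C)CCC(C)(C)O3)cc1` differs from compound 2 by vinylcarbonyl in place of hydrogen on an oxygen on an aromatic ring. The measured step concerns the same vinylcarbonyl group, though entering on a different oxygen, so it bears on the new step only loosely; still, it points toward a lowering rather than a rise. A modest fall in this assay is therefore expected for compound 3, a 2.2-fold lower number from compound 2 to compound 3 (0.35 log units; beyond the scatter). Compound 3 is estimated at 4000 nM, with a range from 1000 nM to 15000 nM.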

Compound 3, half-maximal inhibitory concentration: 290 nM
Compound 3: middle estimate off by 14-fold (1.14 log units), on the high side; the whole stated range lies above it.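

Turning hydroxy into (vinylcarbonyl)oxy on this oxygen on an aromatic ring gives a 31-fold lower number from compound 2 to compound 3 (1.49 log units; beyond the scatter) in this assay, so the read-out is strongly sensitive to what sits at this position. Among these compounds, this is also the first step with a true number at both ends, which means its full size can be read. The earlier step, an at least 3.3-fold lower number from compound 1 to compound 2 (0.52 log units; beyond the scatter), gives only a lower bound on its size, since one of its ends is a limit of the method: the limit of > 30000 nM in this assay, at which 1 of the 3 values shown sits.

The compounds shown leave open whether the drop depends on the vinylcarbonyl group itself or would also appear with an acetyl or propanoyl group on this oxygen. From the compounds shown here alone, it also remains open whether the other vinylcarbonyl ester still matters once this one is in place.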